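This account rests on a few compounds, and the source may have more. Where it says the series, first, only, none or still open, it means among the compounds named here.

Measured compounds in a functional assay on HeLa cells (Homo sapiens) for inhibition, read by CCK-8 assay, with a stated time of 48 h; on this read-out lower numbers stand for stronger inhibition and higher numbers for weaker inhibition:
Compound 1 `O=C(NCCNS(=O)(=O)c1ccc(-c2ccccc2Oc2ccc(O)c(O)c2)s1)Nc1cc(Cl)cc(Cl)c1` gives > 20000 nM, which is a limit of the assay rather than a number.
Compound 2 `O=S(=O)(NCCNC(=S)Nc1cccc(Cl)c1)c1ccc(-c2ccccc2OCc2ccccc2)s1` gives 8400 nM.
Compound 3 `O=S(=O)(NCCNC(=S)Nc1ccc(Cl)cc1)c1ccc(-c2ccccc2OCc2ccccc2)s1` gives 7000 nM.

Among the two numbers shown, compound 3 carries the lowest one, and its nearest measured neighbour is separated from it only by a 1.2-fold lower number from compound 2 to compound 3 (0.08 log units; within the scatter), a gap that the scatter of repeat measurements covers. Compound 1 stands apart as a limit (the limit of > 20000 nM in this assay, at which 1 of the 3 values shown sits), so it gives no number to set against compound 3.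

Compound 4 `Cc1cc(C)cc(NC(=O)NCCNS(=O)(=O)c2ccc(-c3ccccc3OCc3ccccc3)s2)c1` has not yet been measured. It differs from compound 3 in one place: a group of 11 heavy atoms (9 carbon, 1 nitrogen, 1 oxygen; one six-membered aromatic ring of carbon only) in place of a group of 10 heavy atoms (7 carbon, 1 nitrogen, 1 sulfur, 1 chlorine; one six-membered aromatic ring of carbon only), on an amine nitrogen. Among the compounds with values here, the only measured step is a 1.2-fold lower number from compound 2 to compound 3 (0.08 log units; within the scatter); it exchanges 3-chlorophenyl for 4-chlorophenyl and stays within the scatter. It does not test the exchange of a sulfur-bearing group for the oxygen-bearing (3,5-dimethylphenyl)carbamoyl group, so it offers no direct guide. Compound 1 differs from compound 4 in more than one place, and its reading is a limit that cannot be turned into a step. Within the data shown here, with no measured step covering this change, compound 4 is expected to sit near compound 3, with the step of a 1.7-fold higher number from compound 3 to compound 4 (0.23 log units; within the scatter) carrying wide uncertainty and a real chance of a limit-only reading. The estimate for compound 4 in this assay is 12000 nM, within a range from 4000 nM to 40000 nM.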

Compound 4, half-maximal inhibitory concentration: > 50000 nM
Compound 4 ended at the assay's limit (the forecaster's own chance of this, stated with the estimate: 35%); at least 4.1-fold (0.61 log units) between middle value and limit.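

In this assay, compound 4 gives a limit and not a number: the limit of > 50000 nM in this assay, at which 1 of the 4 values shown sits.

Placing (3,5-dimethylphenyl)carbamoyl on the amine nitrogen gives an at least 7.1-fold higher number from compound 3 to compound 4 (0.85 log units; beyond the scatter), and the same comparison with the 3-chlorophenyl compound gives an at least 5.9-fold higher number from compound 2 to compound 4 (0.77 log units; beyond the scatter). Both steps lie beyond the scatter, while the earlier exchange of 3-chlorophenyl for 4-chlorophenyl, a 1.2-fold lower number from compound 2 to compound 3 (0.08 log units; within the scatter), stays within it, so the shown compounds now reveal that changing the whole group at this position can weaken the read-out, which moving the chlorine alone did not do.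

This change, however, alters two things at once: oxygen enters where sulfur leaves, and a dimethylphenyl ring replaces a chlorophenyl ring, so the compounds shown cannot say which part carries the loss; a (4-chlorophenyl)carbamoyl group on the same amine nitrogen would separate the two. From the compounds shown here alone, how far the true value of compound 4 lies beyond its limit also stays open, so both new steps give only the smallest possible size of the change.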